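A few compounds are considered here, and "the series" means these few. Any claim that something is new, unique, unknown or untested is made for them only; others in the source may bear on it.

Compound 2 `CN1CCN(c2ccc(Nc3ncc4nc(Nc5ccc(F)cc5)n([C@@H]5CCN(S(=O)(=O)C6CC6)C5)c4n3)cc2)CC1` gives 2.5 nM in a functional assay on HCC827 cells (Homo sapiens) for antiproliferative activity, read by MTT assay, with a stated time of 72 h (on this read-out higher numbers stand for weaker inhibition and lower numbers for stronger inhibition), the second highest of three numbers; compound 3 `CN1CCN(c2ccc(Nc3ncc4nc(Nc5ccccc5)n([C@@H]5CCN(S(=O)(=O)C6CC6)C5)c4n3)cc2)CC1` gives 0.88 nM, and compound 1 `CN1CCN(c2ccc(Nc3ncc4nc(Nc5ccc(F)cc5)n([C@H]5CCCC(NC(=O)OC(C)(C)C)C5)c4n3)cc2)CC1` gives 120 nM. Among the compounds with values here, the one step that changes a single place, a 2.8-fold lower number from compound 2 to compound 3 (0.45 log units; beyond the scatter), concerns an aromatic substituent and not the saturated ring. Compound 4 `CN1CCN(c2ccc(Nc3ncc4nc(Nc5ccc(F)cc5)n([C@H]5CCN(S(=O)(=O)C6CC6)C5)c4n3)cc2)CC1` differs from compound 2 as follows: the two compounds have the same atoms and bonds and differ only in configuration as drawn: 1 of 1 stereo elements differ; a stereocentre at a saturated ring carbon is drawn R in compound 2 and S in compound 4. Within the data shown here, no measured pair speaks to this change in configuration, so the direction is open; compound 2 and compound 4 are expected to differ by a 4.8-fold higher number from compound 2 to compound 4 (0.68 log units; beyond the scatter), with the inverted configuration expected to be the weaker of the two. Compound 4 is therefore estimated at 12 nM, within a range from 2 nM to 100 nM.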

Compound 4, half-maximal inhibitory concentration: 7.5 nM
Compound 4: the middle estimate sits 1.6-fold (0.20 log units) above what was measured; the range from low to high includes it.
By their numbers in this assay, from the lowest: compound 3; then compound 2; then compound 4; then compound 1.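

In this assay, within the data shown here, the stereocentre at a saturated ring carbon proves to matter in its own right, with a 3.0-fold higher number from compound 2 to compound 4 (0.48 log units; beyond the scatter) as the drawn R gives way to S. No earlier pair had isolated configuration. The gap can be put down to that stereocentre alone because nothing else separates the two compounds: the fact that compounds 2 and 4 differ only in the configuration as drawn.

On these data alone, whether R stays the stronger form with hydrogen in place of fluoro, as in compound 3, remains open. So does whether the preference survives replacing the cyclopropyl sulfonyl group with an acetyl group or a free amine.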